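The compounds below may be only part of what the source reports. "The series", "measured", "known", "first", "only" and "open" are said of these compounds alone.

Measured compounds:

Compound 1 `COc1ccc(-c2cc(/C=C/C(=O)c3ccc(N)cc3)[nH]n2)cc1` — in a functional assay on NCI-H23 cells (Homo sapiens) for cytotoxicity, read by sulforhodamine B assay, with a stated time of 48 h, tested at 100 uM (on this read-out higher numbers stand for a weaker effect at the one concentration tested and lower numbers for a stronger effect), compound 1 gives -62%.
Compound 2 `COc1ccc(-c2cc(/C=C/C(=O)c3ccc(N)cc3)[nH]n2)cc1OC` — in this assay compound 2 gives -51%.
Compound 3 `COc1cc(C(=O)/C=C/c2cc(-c3cc(OC)c(OC)c(OC)c3)n[nH]2)cc(OC)c1OC` — in this assay compound 3 gives -62%.

Compound 2 and compound 1 differ in one place: hydrogen in place of methoxy on an aromatic carbon. In this assay this gave a number 11 percentage points lower from compound 2 to compound 1 (beyond the scatter). The difference between the core of compound 3 and the core of compound 2 is not broken down here; compound 3 sits level with compound 1 at the digits shown, and both are lower than compound 2.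

Compound 4 `COc1ccc(-c2cc(/C=C/C(=O)c3cc(OC)c(OC)c(OC)c3)[nH]n2)cc1OC` is not yet measured. It differs from compound 3 by hydrogen in place of methoxy on an aromatic carbon. This is the same kind of change as that from compound 2 to compound 1, but the surroundings differ: in compound 3 the carbon that loses the methoxy is also meta to a methoxy group, which is not so in compound 2. Among the measured compounds shown here, the one earlier step is the only guide, and it was modest.

For compound 4 in this assay a step of a number 8 percentage points lower from compound 3 to compound 4 (within the scatter) is expected, because the same kind of change gave a number 11 percentage points lower from compound 2 to compound 1 (beyond the scatter). Compound 4 is estimated at -70%, with a range from -90% to -50%.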

Compound 4, a percentage reported as activity, at one concentration (the size of the read-out at that concentration, not a potency): -50%
Compound 4: middle estimate off by 20 percentage points, on the low side; the range from low to high includes it.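

In this assay, hydrogen in place of methoxy on an aromatic carbon gave a number 12 percentage points higher from compound 3 to compound 4 (beyond the scatter), so on the core of compound 3 the effect of this change runs opposite to its effect on the core of compound 2. The two steps are clearly not the same: the same change on two cores in this assay, a number 11 percentage points lower (beyond the scatter) from compound 2 to compound 1 and a number 12 percentage points higher (beyond the scatter) from compound 3 to compound 4, 23 percentage points apart, beyond the scatter of two such steps In this series, then, a step seen with this change on one core cannot be carried to another as a fixed shift in size or direction, though two cores are too few to show which of their structural differences decides the direction, or why the direction reverses.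

On these data alone, it remains open whether the change on a third core would follow either of these steps, or a different one. As far as these compounds go, it is also open how a hydroxyl group, a chlorine atom or an ethoxy group on the same aromatic carbon would read against hydrogen and methoxy on each core.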